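Replacing an Allyloxy Group with Hydrogen

The compounds below may be only part of what the source reports. "The series", "measured", "known", "first", "only" and "open" are said of these compounds alone.

Of the compounds shown here, two of one family have been tested in an ADME assay on DU-145 cells (Homo sapiens) for cytotoxicity, read by MTT assay, with a stated time of 72 h (a lower number here means a stronger inhibitor, a higher number a weaker inhibitor), and both reached only the top of the measurable window. Compound 1, `COC(=O)c1cc(C2=C(c3cc(OC)c(OC)c(OC)c3)C(=O)CC2O[SiH2]C(C)(C)C)ccc1OC`, gives in this assay a limit of > 100 ug/mL rather than a number. Compound 2, `C=CCOc1cc(C2=C(c3cc(OC)c(OC)c(OC)c3)C(=O)C(O)C2)ccc1OC`, likewise gives in this assay only the limit > 100 ug/mL. This is the limit of > 100 ug/mL in this assay, at which 2 of the 2 values shown sit, so nothing in the measured pair separates a stronger compound from a weaker one.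

Compound 3, `COc1ccc(C2=C(c3cc(OC)c(OC)c(OC)c3)C(=O)C(O)C2)cc1`, is not yet measured. It differs from compound 2 in one place: hydrogen in place of allyloxy on an aromatic carbon. Within the data shown here, with no step between measured compounds to lean on, the only guide is that compound 2 sits at the limit in this assay and that compound 1 sits there as well. In this assay the expected step is a step that the limit leaves unreadable from compound 2 to compound 3, small, without a direction that the data can support, and most likely ending once more at a limit. Compound 3 is therefore estimated at 150 ug/mL in this assay, with a likely range from 40 ug/mL to 500 ug/mL.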

Compound 3, half-maximal inhibitory concentration: > 100 ug/mL
Compound 3: no number, only a limit (the forecaster's own chance of this, stated with the estimate: 75%); the middle value is on the limit's open side.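

No step can be read from compound 2 to compound 3, as each gives only a limit rather than a number in this assay: the limit of > 100 ug/mL in this assay, at which 3 of the 3 values shown sit.

The compounds shown leave open whether hydrogen in place of allyloxy changes the strength of inhibition at all, and, if it does, in which direction.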